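Swapping a butyl chain for a ring on the core

This account rests on a few compounds, and the source may have more. Where it says the series, first, only, none or still open, it means among the compounds named here.

Compound 1 `CCCCn1nc(C(=O)N[C@H]2COc3ccccc3N(C)C2=S)nc1Cc1ccccc1` and compound 2 `CCCCCn1nc(C(=O)N[C@H]2COc3ccccc3N(C)C2=S)nc1Cc1ccccc1` share one core and differ only in the chain on an aromatic nitrogen. In a functional assay on HT-29 cells (Homo sapiens) for inhibition, read by luminescence and CellTiter-Glo, with a stated time of 24 h (on this read-out higher numbers stand for an effect only at larger amounts of compound and lower numbers for an effect already at smaller amounts), compound 1 gives 510 nM and compound 2 gives 805 nM; the step of a 1.6-fold higher number from compound 1 to compound 2 (0.20 log units; within the scatter) shows that lengthening the chain changes little. Among the measured compounds shown here, compound 1 holds the lowest of the two numbers so far. Compound 3 `CN1C(=S)[C@@H](NC(=O)c2nc(Cc3ccccc3)n(C3CCOC3)n2)COc2ccccc21` instead carries oxolan-3-yl in place of butyl on an aromatic nitrogen. For the measured compounds named here, no measured step covers a ring in this position, so the expectation for compound 3 is a step of a 1.4-fold higher number from compound 1 to compound 3 (0.14 log units; within the scatter), none beyond the scatter. Compound 3 is therefore estimated at 700 nM, within 250 nM to 2000 nM.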

Compound 3, half-maximal effective concentration: 1580 nM
The estimate for compound 3 lay 2.3-fold (0.35 log units) below the measured number; the measured number falls inside the stated range.
By their numbers in this assay, from the lowest: compounds 1, 2 and 3 (each within the scatter of the next, the first and the last beyond it).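

In this assay, among the compounds shown here, oxolan-3-yl in place of butyl gives a 3.1-fold higher number from compound 1 to compound 3 (0.49 log units; beyond the scatter) and is the first change on this aromatic nitrogen to go beyond the scatter. Set against the longer chain, the same ring gives a 2.0-fold higher number from compound 2 to compound 3 (0.29 log units; within the scatter) and stays within the scatter, so the effect of the ring depends on which chain serves as the comparison. Nothing available explains the result. The compounds shown leave open whether the ring or its oxygen matters more, a question that a cyclopentyl group, the carbon-only ring, could address.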